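Swapping the aromatic ring on a guanidine-type agonist

The source may report more compounds than this note shows. Statements on the series, on what has been measured and on what is new or still open speak of the compounds shown alone.

Measured so far:
- compound 1, `Cc1nc(N)sc1CCCN/C(N)=N/C(=O)N[C@@H](C)c1ccccc1`: 1.08
- compound 2, `Cc1nc(N)sc1CCCN/C(N)=N/C(=S)N[C@H](C)c1ccccc1`: 0.87

Of the compounds shown here, two have been measured in a functional assay on Right cardiac atrium for agonist activity at histamine H2 receptor (Cavia porcellus), with a stated time of 30 min, in the presence of a further agent that is not named here; a lower number here means a smaller maximal response, a higher number a larger maximal response. Compound 1 gives 1.08, the higher of the two numbers, and compound 2 gives 0.87, a difference that lies beyond the usual scatter of this kind of measurement. Compound 2 differs from compound 1 in more than one place, so these two values say only where each stands, not what any single change does.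

Compound 3, `Cc1nc(N)sc1CCCN/C(N)=N/C(=O)NC(C)c1cccs1`, has not yet been measured. It differs from compound 1 in one place: 1-(thiophen-2-yl)ethyl in place of 1-phenylethyl on an amide-type nitrogen. For the measured compounds named here, no measured pair in this set isolates a change of this kind, so the expectation rests on compound 1 alone.

Because compound 1 reaches 1.08 and the change concerns only the aromatic ring carried by the 1-substituted ethyl group, the step a number 0.080 lower from compound 1 to compound 3 (within the scatter) is expected to stay within the scatter, with no direction asserted. Compound 3 is therefore estimated at 1 in this assay, with a range from 0.85 to 1.15.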

Compound 3, intrinsic activity: the largest response reached, as a fraction of the reference agonist's: 0.88
Beside the measured number, compound 3's estimate is 0.12 above it; the range from low to high includes it.
By their numbers in this assay, from the lowest: compounds 2 and 3 (each within the scatter of the next); then compound 1.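

In this assay, for the compounds shown here, replacing 1-phenylethyl with 1-(thiophen-2-yl)ethyl on the amide-type nitrogen gives a number 0.20 lower from compound 1 to compound 3 (beyond the scatter), the first single-place change that can be read in this set, and it shows that the maximal response is sensitive to the aromatic ring carried at this position. The change is not only a swap of rings, however: 1-phenylethyl has a defined stereocentre, whereas no defined stereocentre is listed for 1-(thiophen-2-yl)ethyl, so the step cannot be assigned to the ring alone. No separate measurement is available to explain the step.

The compounds shown leave open whether each single mirror-image form of compound 3 would match compound 1 more closely, which would separate the effect of the ring from that of the undefined stereocentre. They also leave open whether the step follows from moving to a five-membered ring in general or is particular to thiophene, a question that a 1-(furan-2-yl)ethyl or a 1-(pyridin-2-yl)ethyl group at the same nitrogen could help to answer.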